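Series notes: ring methyl removal from compound 2

The source may report more compounds than this note shows. Statements on the series, on what has been measured and on what is new or still open speak of the compounds shown alone.

In a functional assay on SK-MEL-5 cells (Homo sapiens) for antiproliferative activity (on this read-out lower numbers stand for stronger inhibition of growth and higher numbers for weaker inhibition of growth), compound 1 `Cc1cccc(-c2cc(O)c3cc(C)cnc3n2)c1` gives 288 nM, compound 3 `Cc1cnc2[nH]c(-c3cccc(Cl)c3)cc(=O)c2c1` gives 70.8 nM, and compound 2 `Cc1cc(C)c2c(O)cc(-c3ccc4ccccc4c3)nc2n1` gives 2190 nM. Compound 2 thus stands with the highest number of the three; its gap to compound 1 and its larger gap to compound 3 both lie beyond the scatter. Compound 4 `Cc1ccnc2nc(-c3ccc4ccccc4c3)cc(O)c12` is not yet measured. It differs from compound 2 by hydrogen in place of methyl on an aromatic carbon. Among the compounds with values here, no measured pair in the set shows this change on its own, so the size of the step in this assay cannot be read from the data; only the loss of a single methyl, with no change in ring count, donors or acceptors, is involved. A step toward a lower number is expected, but a modest one, likely close to the scatter rather than far beyond it. Compound 4 is estimated at 1300 nM, with a range from 450 nM to 4000 nM, which corresponds to an expected step of a 1.7-fold lower number from compound 2 to compound 4 (0.23 log units; within the scatter).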

Compound 4, concentration for 50% growth inhibition: 437 nM
Compound 4: middle estimate off by 3.0-fold (0.47 log units), on the high side; the whole stated range lies above it.
By their numbers in this assay, from the lowest: compound 3; then compounds 1 and 4 (each within the scatter of the next); then compound 2.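

In this assay, within the data shown here, hydrogen in place of methyl on the aromatic carbon next to the ring nitrogen gives a 5.0-fold lower number from compound 2 to compound 4 (0.70 log units; beyond the scatter), the first reading of this change. The position is therefore not silent: the loss of a single methyl, with no change in ring count, donors or acceptors, is enough to move the number beyond the scatter. No measurement on hand bears on what lies behind this step.

On these data alone, the reading rests on one pair, both members of which keep the second methyl on the same ring, so it remains open whether the step holds when that methyl is absent or the aryl group differs. Also open, as far as these compounds go, is how this carbon responds to other groups, such as ethyl, methoxy or an amine, in place of methyl or hydrogen.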